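A few compounds are considered here, and "the series" means these few. Any claim that something is new, unique, unknown or untested is made for them only; others in the source may bear on it.

Working notes on the series. In an ADME assay on HOS cells (Homo sapiens) for cytotoxicity (a higher number here means that more compound is tolerated, a lower number that less compound is tolerated), compound 1 (`CN(Cc1nc2ccccc2n1CC1CCNC1)C1CCCc2cccnc21`) gives 7700 nM and compound 2 (`CN1CC(Cn2c(CN(C)C3CCCc4cccnc43)nc3ccccc32)C1`) gives 14000 nM. Among the compounds with values here, these two values lie within the scatter of each other, so compound 2 cannot be separated from its only measured neighbour.

Compound 3 (`CN(Cc1nc2ccccc2n1CC1CNC1)C1CCCc2cccnc21`) is the next point, and it differs from compound 2 as follows: hydrogen in place of methyl on an amine nitrogen in a ring. In words, this is hydrogen in place of methyl on an amine nitrogen in a ring.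

Within the data shown here, only one measured step bears on this change: a 1.8-fold higher number from compound 1 to compound 2 (0.26 log units; within the scatter). That step replaces pyrrolidin-3-yl with 1-methylazetidin-3-yl, so the ring and the methyl change together, and the methyl is not isolated. Among the measured compounds shown here, no measured pair shows the removal of the methyl alone. Even so, the combined change stayed within the scatter, so no shift beyond the scatter is expected in this assay, and any direction is only weakly supported.

The expected change is a 1.4-fold lower number from compound 2 to compound 3 (0.15 log units; within the scatter), which remains within the scatter. For compound 3 the estimated value is 10000 nM, with an expected range of 4500 nM to 22000 nM.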

Compound 3, half-maximal cytotoxic concentration: 15000 nM
Compound 3: the middle estimate sits 1.5-fold (0.18 log units) below what was measured, and the stated range covers the measured number.
By their numbers in this assay, from the lowest: compounds 1, 2 and 3 (each within the scatter of the next).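

Within the data shown here, with compound 3 the methyl on the amine nitrogen of the four-membered ring is taken on its own for the first time: in this assay hydrogen in place of methyl gives a 1.1-fold higher number from compound 2 to compound 3 (0.03 log units; within the scatter) and so does not separate the two compounds. The ring change can now also be read without the methyl, as azetidin-3-yl in place of pyrrolidin-3-yl gives a 1.9-fold higher number from compound 1 to compound 3 (0.29 log units; within the scatter) and also stays within the scatter. Across these three compounds, neither the methyl on this nitrogen nor the change between the two rings moves the number beyond the scatter, and no supporting data offer any account of this.

Open is whether a larger group on this amine nitrogen, such as ethyl, a longer alkyl chain or acetyl, would also stay within the scatter, since the compounds shown carry only hydrogen or methyl there. Also open, going by these compounds, is whether a carboxylic acid or a primary amine on the (azetidin-3-yl)methyl side chain, or a change elsewhere on the shared core, would give a step beyond the scatter in this assay and so show where tolerance in these cells depends on structure.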